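Swapping tert-butyl for isobutyl on a boron-bearing carbon

A few compounds are considered here, and "the series" means these few. Any claim that something is new, unique, unknown or untested is made for them only; others in the source may bear on it.

Compound 1 `CC(C)(C)[C@H](NC(=O)N1C/C(=C\c2ccc(F)cc2)C(=O)/C(=C/c2ccc(F)cc2)C1)B1OC(C)(C)C(C)(C)O1` gives 828 nM
Compound 2 `CC(C)C[C@H](NC(=O)N1CCN(C(=O)N2C/C(=C\c3ccc(F)cc3)C(=O)/C(=C/c3ccc(F)cc3)C2)CC1)B1OC(C)(C)C(C)(C)O1` gives 1630 nM

In a functional assay on HCT-116 cells (Homo sapiens) for antiproliferative activity, read by MTT assay, with a stated time of 72 h (a lower number here means a stronger inhibitor, a higher number a weaker inhibitor), compound 1 gives 828 nM and compound 2 gives 1630 nM as its number. These two values lie within the usual scatter of each other, so neither can be ranked.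

Compound 3 `CC(C)C[C@H](NC(=O)N1C/C(=C\c2ccc(F)cc2)C(=O)/C(=C/c2ccc(F)cc2)C1)B1OC(C)(C)C(C)(C)O1` has not yet been measured. It keeps the core of compound 1 and changes one group: isobutyl in place of tert-butyl on a saturated chain carbon bound to an amide-type nitrogen and a boron atom. The two groups are the same size by count, but their atoms are joined differently.

Among the compounds with values here, no measured pair shows what this swap does on its own. Isobutyl does occur in compound 2 (1630 nM), whose number stays within the scatter of compound 1. In this assay no step beyond the scatter is therefore expected, in either direction. The estimate means only a small expected step (a 1.1-fold lower number from compound 1 to compound 3 (0.04 log units; within the scatter)) and no more. Compound 3 is expected to give about 750 nM with an estimated range of 300 nM to 1900 nM when it is tested.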

Compound 3, half-maximal inhibitory concentration: 824 nM
The estimate for compound 3 lay 1.1-fold (0.04 log units) below the measured number; low and high end bracket the measured number.
By their numbers in this assay, from the lowest: compounds 3, 1 and 2 (each within the scatter of the next).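

In this assay the swap of tert-butyl for isobutyl can now be read on its own, and it amounts to a 1.0-fold lower number from compound 1 to compound 3 (0.00 log units; within the scatter) with nothing else in the molecule altered. Within the data shown here, earlier, isobutyl had been seen only in compound 2, which differs from compound 1 in more than one place, so that pair could not isolate this group; this pair shows that, on this core, the two ways of joining these carbons on the boron-bearing carbon cannot be told apart in this cell read-out. No measurement shown here speaks to the reason for this result.

From the compounds shown here alone, both groups consist of carbon and hydrogen only, so it remains open how this position would respond to a different kind of group, such as an amine, a carboxylic acid or a longer chain. Compound 2 has no tert-butyl partner among the compounds shown, so it also remains open whether the swap would read the same on its larger framework.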